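The source may report more compounds than this note shows. Statements on the series, on what has been measured and on what is new or still open speak of the compounds shown alone.

Three compounds have been measured in a functional assay on SK-N-SH cells (Homo sapiens) for cytotoxicity, read by MTT assay, with a stated time of 48 h; a higher number here means a weaker inhibitor, a lower number a stronger inhibitor:

Compound 1 `COc1ccc(/C=C/c2cc(OC)c(OC)c(OC)c2-c2ccc3ccccc3c2)cc1` gives 16000 nM.
Compound 2 `COc1ccc(/C=C/c2cc(OC)c(OC)c(OC)c2-c2ccc(Cl)cc2)cc1` gives 15000 nM.
Compound 3 `C=C(c1ccc(OC)cc1)c1cc(OC)c(OC)c(OC)c1-c1ccc2ccccc2c1` gives 6000 nM.

Compound 1 and compound 2 differ only in 4-chlorophenyl in place of naphthalen-2-yl on an aromatic carbon, and that change produced a 1.1-fold lower number from compound 1 to compound 2 (0.03 log units; within the scatter). Compound 1 and compound 3 share the same atoms joined differently, the difference being (1-(4-methoxyphenyl)ethenyl in place of 2-(4-methoxyphenyl)ethenyl on an aromatic carbon), which gave a 2.7-fold lower number from compound 1 to compound 3 (0.43 log units; beyond the scatter) in this assay. Compound 3 thus has the lowest number of the three.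

Compound 4 `C=C(c1ccc(OC)cc1)c1cc(OC)c(OC)c(OC)c1-c1ccc(Cl)cc1` has not yet been measured. It stands to compound 3 as compound 2 stands to compound 1: the change is 4-chlorophenyl in place of naphthalen-2-yl on an aromatic carbon. The surroundings are not identical. In compound 1 the place is ortho to a 2-(4-methoxyphenyl)ethenyl group, whereas in compound 3 it is ortho to a 1-(4-methoxyphenyl)ethenyl group, so this is the same kind of change rather than the same change. From compound 3 to compound 4 a step of a 1.1-fold lower number from compound 3 to compound 4 (0.04 log units; within the scatter) is expected, resting on the earlier 1.1-fold lower number from compound 1 to compound 2 (0.03 log units; within the scatter). Compound 4 is therefore estimated at 5500 nM in this assay, most likely between 2500 nM and 12000 nM.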

Compound 4, half-maximal inhibitory concentration: 15000 nM
Estimate against measurement, compound 4: 2.7-fold (0.44 log units) below; the whole stated range lies below it.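

In this assay, the change from naphthalen-2-yl to 4-chlorophenyl did not carry over cleanly from one core to the other: it gave a 2.5-fold higher number from compound 3 to compound 4 (0.40 log units; beyond the scatter), whereas the earlier case gave a 1.1-fold lower number from compound 1 to compound 2 (0.03 log units; within the scatter). Set side by side, the two results differ by more than repeated measurements would explain: the same change on two cores in this assay, a 1.1-fold lower number (0.03 log units; within the scatter) from compound 1 to compound 2 and a 2.5-fold higher number (0.40 log units; beyond the scatter) from compound 3 to compound 4, 2.7-fold (0.43 log units) apart, beyond the scatter of two such steps. This shows that, for this pair of cores, the outcome of the change depends on whether the core carries the 1-(4-methoxyphenyl)ethenyl or the 2-(4-methoxyphenyl)ethenyl group, but it does not show why, nor how the change would behave on any further core.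

All the compounds shown keep the methoxy groups of the shared core and the 4-methoxyphenyl group, and only naphthalen-2-yl or 4-chlorophenyl occupies the aromatic carbon in question. From the compounds shown here alone, whether an amine, a carboxylic acid or a hydroxyl group at that carbon would show a similar dependence on the core remains open.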